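A few compounds are considered here, and "the series" means these few. Any claim that something is new, unique, unknown or untested is made for them only; others in the source may bear on it.

Measured compounds in this series:

Compound 1 `COc1cc(/C=C/C(=O)/C=C(/C=C/c2ccc(OC(C)=O)c(OC)c2)NC2CCCCC2)ccc1OC(C)=O`: in a functional assay on CHO-K1 cells (Cricetulus griseus) for inhibition, read by sulforhodamine B assay, with a stated time of 72 h (a higher number here means a weaker inhibitor, a lower number a stronger inhibitor), compound 1 gives only the assay limit > 25000 nM.
Compound 2 `COc1cc(/C=C/C(=O)/C=C(/C=C/c2ccc(OC(C)=O)c(OC)c2)NCC(C)C)ccc1OC(C)=O`: in this assay compound 2 also gives only the assay limit > 25000 nM.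
Compound 3 `COc1cc(/C=C/C(=O)/C=C(/C=C/c2ccc(O)c(OC)c2)NC2CCCCC2)ccc1O`: in this assay compound 3 likewise gives only the assay limit > 25000 nM.

All three values sit at the limit of > 25000 nM in this assay, at which 3 of the 3 values shown sit. The change from compound 1 to compound 2 is isobutyl in place of cyclohexyl on an amine nitrogen, and the step that the two limits leave unreadable from compound 1 to compound 2. How the core of compound 1 differs from the core of compound 3 is not broken down here.

Compound 4 `COc1cc(/C=C/C(=O)/C=C(/C=C/c2ccc(O)c(OC)c2)NCC(C)C)ccc1O` is not yet measured in this assay. It arises from compound 3 by the same change, (isobutyl in place of cyclohexyl on an amine nitrogen). Compound 3 shows only a limit > 25000 nM. The matching step that the two limits leave unreadable from compound 1 to compound 2 gave no readable size. Compound 4 is therefore expected to stay at the limit too, with an estimate of 40000 nM, between 15000 nM and 150000 nM, an expected step that the limit leaves unreadable from compound 3 to compound 4 that is essentially flat.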

Compound 4, half-maximal inhibitory concentration: > 25000 nM
Compound 4 was reported as a limit (the forecaster's own chance of this, stated with the estimate: 85%); the middle value does not contradict the limit.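

No step can be read from compound 3 to compound 4, since both values are limits: the limit of > 25000 nM in this assay, at which 4 of the 4 values shown sit. The compounds shown leave open whether isobutyl or cyclohexyl on the amine nitrogen makes any difference to inhibition.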